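Replacing the amide of compound 2 with a carboxylic acid

The compounds below may be only part of what the source reports. "The series", "measured", "known", "first", "only" and "open" are said of these compounds alone.

In a functional assay on HeLa cells (Homo sapiens) for cytotoxicity, read by MTT assay, with a stated time of 24 h (a lower number here means a stronger inhibitor, a higher number a weaker inhibitor), compound 2 `C=CC1=C(C(=O)NC2CCCCC2)C(c2ccc(OC)c(OC)c2)OC1` gives 5540 nM, the lowest of the two numbers in hand. Compound 3 `C=CC1=C(C(=O)NC2CCCCC2)C(c2ccc(OC)cc2)OC1` gives 24800 nM in this assay, and a 4.5-fold higher number from compound 2 to compound 3 (0.65 log units; beyond the scatter). Compound 1 `C=CC1=C(C(=O)NCCCCC)C(c2ccc(Cl)c(Cl)c2)OC1` reaches only a limit in this assay, namely > 100000 nM; this is the limit of > 100000 nM in this assay, at which 1 of the 3 values shown sits. Compound 4 `C=CC1=C(C(=O)O)C(c2ccc(OC)c(OC)c2)OC1` differs from compound 2 by hydroxy in place of cyclohexylamino on a carbonyl carbon. Among the measured compounds shown here, the single measured step, between compound 2 and compound 3, touches the aromatic ring and not the carbonyl, so it offers no direct guide to this change. With the whole cyclohexylamino group removed, the expected step is beyond the scatter and toward a higher number, as a 9.0-fold higher number from compound 2 to compound 4 (0.96 log units; beyond the scatter). Compound 4 is therefore estimated at 50000 nM in this assay, within 10000 nM to 200000 nM.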

Compound 4, half-maximal inhibitory concentration: 18000 nM
Estimate against measurement, compound 4: 2.8-fold (0.44 log units) above; measured number inside the range.
By their numbers in this assay, from the lowest: compound 2; then compounds 4 and 3 (each within the scatter of the next). At a limit, above all of these: compound 1.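

In this assay, the carbonyl carbon now has a measured step of its own, with hydroxy in place of cyclohexylamino giving a 3.2-fold higher number from compound 2 to compound 4 (0.51 log units; beyond the scatter). The step is modest, so removing the six-membered carbon ring does not abolish the measurable effect on the cells. Nothing shown accounts for the size of this step.

The compounds shown leave open how a methyl ester or an unsubstituted amide on this carbonyl carbon would compare with compound 2 and compound 4. They also leave open whether removing a methoxy group from compound 4 would produce a step like that seen in the amide series.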